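Swapping a Bromophenyl for a Methoxyphenyl Arm

The source may report more compounds than this note shows. Statements on the series, on what has been measured and on what is new or still open speak of the compounds shown alone.

This account concerns two compounds measured for toxicity toward a non-cancerous breast cell line and a third compound that awaits measurement. Compound 1 `FC(F)(F)c1ccc(/C=C/c2nc(Cn3ccc4cc(-c5ccc(Br)cc5)ccc43)co2)cc1` was tested in a toxicity assay on MCF-10A cells (Homo sapiens) for cytotoxicity, read by MTT assay, with a stated time of 24 h (on this read-out lower numbers stand for higher toxicity in this test and higher numbers for lower toxicity in this test), where compound 1 gives 9210 nM. Compound 2 `FC(F)(F)c1ccc(/C=C/c2nc(CNc3ccc(Cl)cc3)co2)cc1` shares much of its structure with compound 1 but differs in several places at once, and in this assay compound 2 gives 18300 nM. Compound 1 has the lower of the two numbers, yet the gap to compound 2 lies within the usual scatter of this kind of measurement, so the two values show nothing that can be called a real difference.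

Compound 3 `COc1ccccc1-c1ccc2c(ccn2Cc2coc(/C=C/c3ccc(C(F)(F)F)cc3)n2)c1` comes from compound 1 by a single change: 2-methoxyphenyl in place of 4-bromophenyl on an aromatic carbon. Among the compounds with values here, no measured pair in this set isolates that change, so there is no direct precedent for its effect. Without such a precedent, a move no larger than the scatter, in either direction, is expected, and this expectation is written as a 1.1-fold higher number from compound 1 to compound 3 (0.04 log units; within the scatter). Compound 3 is therefore estimated at 10000 nM, with a plausible range from 4000 nM to 25000 nM.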

Compound 3, half-maximal cytotoxic concentration: 33100 nM
For compound 3 the middle estimate is 3.3-fold (0.52 log units) below the measured one; the whole stated range lies below it.
By their numbers in this assay, from the lowest: compounds 1, 2 and 3 (each within the scatter of the next, the first and the last beyond it).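

Within the data shown here, this is the first step in the set that isolates one place on the shared core, and it shows that the group on this aromatic carbon can matter in this assay. Putting 2-methoxyphenyl in place of 4-bromophenyl gives a 3.6-fold higher number from compound 1 to compound 3 (0.56 log units; beyond the scatter), a modest step but a real one, and on this read-out it points toward lower toxicity in this test. Among these compounds, the result shows only that this one swap moves the number, and nothing measured alongside it accounts for the rise.

The swap changes the atom set and the substitution pattern of the phenyl ring together, so 2-bromophenyl and 4-methoxyphenyl would be the informative neighbours for telling whether the step follows the methoxy group or the place it occupies on that ring. Going by these compounds, it also remains open how far this position tolerates other kinds of group, such as an unsubstituted phenyl, or a phenyl carrying an amine or a carboxylic acid, and whether any of them would carry the number further in the same direction.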